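This account rests on a few compounds, and the source may have more. Where it says the series, first, only, none or still open, it means among the compounds named here.

Compound 1 `CC(C)c1cccc(NC(=O)Nc2cccc(-c3cccc4[nH]nc(N)c34)c2)c1` gives 1420 nM in a functional assay on A549 cells (Homo sapiens) for inhibition, read by MTT assay, with a stated time of 48 h; on this read-out higher numbers stand for weaker inhibition and lower numbers for stronger inhibition
Compound 2 `Nc1n[nH]c2cccc(-c3cccc(NC(=O)Nc4cc(C(F)(F)F)cc(C(F)(F)F)c4)c3)c12` gives 1510 nM in this assay

Compound 2 stands level with compound 1, as the gap between their two numbers lies within the usual scatter of repeated measurements. Neither can be ranked above the other.

Compound 3 `Nc1n[nH]c2cccc(-c3cccc(NC(=O)Nc4cccc(C(F)(F)F)c4)c3)c12` is compound 2 with one change (hydrogen in place of trifluoromethyl on an aromatic carbon), namely hydrogen in place of trifluoromethyl on an aromatic carbon. Among the measured compounds shown here, no measured pair here differs in one place only, so this change has no direct precedent. For the measured compounds named here, the one available guide is indirect. Compound 1 and compound 2 carry different groups on that ring, yet compound 2 at 1510 nM stays within the scatter of compound 1 at 1420 nM in this assay. On this evidence, no step beyond the scatter is expected, in either direction. The estimate amounts to a 1.0-fold lower number from compound 2 to compound 3 (0.00 log units; within the scatter), an expected step within the scatter. Two measurements are thin support, so the range is kept wide. Compound 3 is expected at 1500 nM, within an estimated range of 600 nM to 3500 nM for now.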

Compound 3, half-maximal inhibitory concentration: 1950 nM
Compound 3: middle estimate off by 1.3-fold (0.11 log units), on the low side; low and high end bracket the measured number.
By their numbers in this assay, from the lowest: compounds 1, 2 and 3 (each within the scatter of the next).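

Among the compounds shown here, this is the first direct reading of hydrogen in place of trifluoromethyl on this aromatic carbon, and the step measured in this assay is a 1.3-fold higher number from compound 2 to compound 3 (0.11 log units; within the scatter). The comparison with compound 1 adds a second direct reading, trifluoromethyl in place of isopropyl on an aromatic carbon, which gives a 1.4-fold higher number from compound 1 to compound 3 (0.14 log units; within the scatter) in the same assay. Across these three compounds, then, neither one-place change moves the number beyond the scatter, so hydrogen, isopropyl and trifluoromethyl cannot be ranked here, and no measurement on hand offers an explanation for that.

Still open, from the compounds shown here alone, is whether an amine, a carboxylic acid or a methoxy group on that aromatic carbon would give a step beyond the scatter, and the same question applies to a ring with hydrogen in place of both trifluoromethyl groups of compound 2. All three compounds also share the rest of their structure, so they say nothing about how a change elsewhere, such as in the shared core, would read in this assay.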